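The source may report more compounds than this note shows. Statements on the series, on what has been measured and on what is new or still open speak of the compounds shown alone.

In a functional assay on MCF7 cells (Homo sapiens) for antiproliferative activity (a higher number here means a weaker inhibitor, a lower number a stronger inhibitor), three compounds built on one shared core have been measured. Compound 1 `CSc1nc2c([nH]1)C(=O)C=C(N(C)C)C2=O` gives only a limit in this assay, > 90 uM. Compound 1 therefore stands at the limit of > 90 uM in this assay, at which 1 of the 3 values shown sits, with no exact number of its own. Compound 2 `CSc1nc2c([nH]1)C(=O)C=C(Br)C2=O` gives 62.8 uM in this assay, and compound 3 `COC1=CC(=O)c2[nH]c(SC)nc2C1=O` gives 36 uM. Every measured step changes the group on the double-bonded ring carbon: an at least 1.4-fold lower number from compound 1 to compound 2 (0.15 log units; that floor lies within the scatter), an at least 2.5-fold lower number from compound 1 to compound 3 (0.39 log units; beyond the scatter) and a 1.7-fold lower number from compound 2 to compound 3 (0.24 log units; within the scatter).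

Compound 4 `CN(C)C1=CC(=O)c2[nH]c(-c3ccccn3)nc2C1=O` differs from compound 1 at a different place: pyridin-2-yl in place of methylsulfanyl on an aromatic carbon. None of the three measured steps touches that aromatic carbon, so they give no direct guide to the size or direction of this change; they show only where compound 1 stands in this assay. Within the data shown here, with no comparable step among the measured compounds, compound 4 is expected to stay close to compound 1, an at least 1.2-fold lower number from compound 1 to compound 4 (0.10 log units; that floor lies within the scatter), and the estimate is uncertain. The estimate for compound 4 in this assay is 70 uM, within a range from 25 uM to 200 uM.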

Compound 4, concentration for 50% inhibition: > 90 uM
Compound 4: only a limit was reported; the forecaster's own chance of this, stated with the estimate: 45%; at least 1.2-fold (0.10 log units) between middle value and limit.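

Compound 4, like compound 1, gives only a limit in this assay: the limit of > 90 uM in this assay, at which 2 of the 4 values shown sit.

With a limit on each side, the step from compound 1 to compound 4 cannot be read. The compounds shown leave open how large the swap of methylsulfanyl for pyridin-2-yl is, and in which direction it goes.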